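The source may hold more compounds than are shown below. What is called first, only, known or untested is meant among the compounds shown, and "the series" means these compounds.

In a functional assay on K562 cells (Homo sapiens), read by MTT assay, with a stated time of 72 h (a higher number here means a weaker inhibitor, a lower number a stronger inhibitor), compound 1 `COc1ncnc2c1c(-c1ccccc1)cn2[C@@H]1O[C@H](CO)[C@@H](O)[C@H]1O` reads > 20000 nM, which is a limit of the assay and not a number. Compound 2 `COc1ncnc2c1c(-c1cc3ccccc3o1)cn2[C@@H]1O[C@H](CO)[C@@H](O)[C@H]1O` gives 13100 nM. For the measured compounds named here, compound 3 `CSc1ncnc2c1c(-c1ccoc1)cn2[C@@H]1O[C@H](CO)[C@@H](O)[C@H]1O` gives 3250 nM, the lower of the two actual numbers so far, and its gap to compound 2 lies beyond the scatter.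

The next structure is compound 4 `CSc1ncnc2c1c(-c1cccs1)cn2[C@@H]1O[C@H](CO)[C@@H](O)[C@H]1O`, with thiophen-2-yl in place of furan-3-yl on an aromatic carbon of the five-membered aromatic ring with 1 nitrogen: thiophen-2-yl in place of furan-3-yl on an aromatic carbon. Going by the values given here, only one measured step exchanges one aromatic group for another, with 1-benzofuran-2-yl in place of phenyl: an at least 1.5-fold lower number from compound 1 to compound 2 (0.18 log units; that floor lies within the scatter). That step starts from a limit, its floor stays within the scatter, and it involves neither group in the present change, so it offers little guidance. Among the compounds with values here, no measured pair compares furan-3-yl with thiophen-2-yl directly.

The expectation in this assay therefore stays anchored on compound 3 at 3250 nM, and no step beyond the scatter is expected in either direction. The estimated step is a 1.3-fold lower number from compound 3 to compound 4 (0.11 log units; within the scatter). The expected value for compound 4 is 2500 nM, with an estimated range from 700 nM to 9000 nM.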

Compound 4, half-maximal inhibitory concentration: > 20000 nM
Compound 4 gave a limit, no number; the forecaster's own chance of this, stated with the estimate: 5%; middle value at least 8.0-fold (0.90 log units) away from the limit.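

In this assay, for the compounds shown here, thiophen-2-yl in place of furan-3-yl on this aromatic carbon gives an at least 6.1-fold higher number from compound 3 to compound 4 (0.78 log units; beyond the scatter), the first step between compounds differing in one place that is printed beyond the scatter. The position therefore does not treat these two groups alike, although each is one five-membered aromatic ring with 1 hetero atom, with the same counts of heavy atoms, hydrogen-bond donors and hydrogen-bond acceptors. The value of compound 4 is a limit of the assay and not a number, so the step gives only a floor and its full size stays unknown: the limit of > 20000 nM in this assay, at which 2 of the 4 values shown sit.

The change swaps oxygen for sulfur and also moves the ring carbon of attachment, and the compounds shown cannot separate these two parts; furan-2-yl or thiophen-3-yl on the same carbon would be needed to do so. Also open, as far as these compounds go, is whether any group at this position can give a lower number than furan-3-yl, for example a ring bearing an amine or a carboxylic acid, and whether the outcome holds with a methoxy group in place of the methylsulfanyl group on the shared core.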